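Methoxymethoxy on compound 1: expected step

The compounds below may be only part of what the source reports. "The series", "measured", "known", "first", "only" and "open" are said of these compounds alone.

Within the data shown here, in a functional assay on HL-60 cells (Homo sapiens) for cytotoxicity, read by WST assay, with a stated time of 48 h (a lower number here means that less compound is needed, a higher number that more compound is needed for the effect), compound 1 (`O=C1OC[C@H](Cc2ccccc2)[C@H]1Cc1ccccc1`) gives 77000 nM, the highest of the three numbers so far. Compound 2 (`CCCCOc1ccccc1C[C@H]1C(=O)OC[C@@H]1Cc1ccccc1`) gives 20000 nM, and compound 3 (`O=C1OC[C@H](Cc2ccccc2)[C@H]1Cc1ccccc1C(F)(F)F`) gives 37000 nM.

Compound 4 (`COCOc1ccc(C[C@H]2C(=O)OC[C@@H]2Cc2ccccc2)cc1`) carries methoxymethoxy in place of hydrogen on an aromatic carbon, para to a large group: methoxymethoxy in place of hydrogen on an aromatic carbon.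

Two measured steps also start from compound 1 and change it in one place. Butoxy gives a 3.9-fold lower number from compound 1 to compound 2 (0.59 log units; beyond the scatter), and trifluoromethyl gives a 2.1-fold lower number from compound 1 to compound 3 (0.32 log units; beyond the scatter). Both are modest and point the same way, while the two substituted compounds differ only within the scatter, with a 1.9-fold higher number from compound 2 to compound 3 (0.27 log units; within the scatter). Methoxymethoxy itself has no measured precedent here, so this support is indirect.

A modest step towards a lower number is therefore expected in this assay, estimated as a 2.2-fold lower number from compound 1 to compound 4 (0.34 log units; beyond the scatter). The estimated value for compound 4 is 35000 nM, with an expected range of 15000 nM to 80000 nM.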

Compound 4, half-maximal effective concentration: 71000 nM
For compound 4 the middle estimate is 2.0-fold (0.31 log units) below the measured one, within the range that was stated.
By their numbers in this assay, from the lowest: compounds 2, 3, 4 and 1 (each within the scatter of the next, the first and the last beyond it).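

In this assay, methoxymethoxy on an aromatic carbon, para to a large group, leaves the number level with that of the unsubstituted parent (a 1.1-fold lower number from compound 1 to compound 4 (0.04 log units; within the scatter)). A new substituent on an aromatic carbon therefore does not by itself shift the number, unlike butoxy (a 3.9-fold lower number from compound 1 to compound 2 (0.59 log units; beyond the scatter)) and trifluoromethyl (a 2.1-fold lower number from compound 1 to compound 3 (0.32 log units; beyond the scatter)), so compound 4 goes against the pattern those two steps suggested. No available data account for this difference.

Compound 4 differs from compounds 2 and 3 in more than one respect, so the effect of the group cannot yet be separated from the effect of its place on the ring. Open questions are how butoxy itself, a hydroxy group, an amine or a carboxylic acid would behave para to a large group, and whether methoxymethoxy would stay level with compound 1 at another ring carbon.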